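A few compounds are considered here, and "the series" means these few. Any claim that something is new, unique, unknown or untested is made for them only; others in the source may bear on it.

Working notes on the series.

Compound 1 `CCC1=C(C(=O)OCC2CCCCC2)[C@H](c2ccc(O)c(Cl)c2)NC(=O)N1` and compound 2 `CCC1=C(C(=O)CCC2CCCCCC2)[C@H](c2ccc(O)c(Cl)c2)NC(=O)N1` share a core and differ in one place, 2-cycloheptylethyl in place of cyclohexylmethoxy on a carbonyl carbon. In an ADME assay on cells (Homo sapiens) for cytotoxicity (on this read-out higher numbers stand for lower toxicity in this test and lower numbers for higher toxicity in this test), compound 1 gives > 10000 nM, which is a limit of the test and not a number. In this assay compound 2 gives > 10000 nM, likewise a limit. The step that the two limits leave unreadable from compound 1 to compound 2 therefore cannot be sized; both values sit at the limit of > 10000 nM in this assay, at which 2 of the 2 values shown sit.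

Compound 3 `CCC1=C(C(=O)CCc2ccccc2)[C@H](c2ccc(O)c(Cl)c2)NC(=O)N1` is not yet measured. It differs from compound 2 by phenyl in place of cycloheptyl on a saturated chain carbon, two bonds along the chain from a carbonyl carbon. Among the compounds with values here, no measured step in this set bears on that change directly; the only measured step is the one from compound 1 to compound 2, and it is unreadable. The two limits so far give no sign of toxicity within the tested range for either compound.

For compound 3 the expected outcome in this assay is an estimate of 20000 nM, with a range from 5000 nM to 80000 nM. The estimated step that the limit leaves unreadable from compound 2 to compound 3 is expected to stay within the scatter, with a high chance that the test again reports only a limit.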

Compound 3, half-maximal cytotoxic concentration: > 10000 nM
Compound 3 gave a limit, no number; the forecaster's own chance of this, stated with the estimate: 80%; the middle value does not contradict the limit.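

In this assay, within the data shown here, compound 3 gives > 10000 nM as a limit and not a number, so the steps from compound 1 and compound 2 to compound 3 cannot be read and no new step stands: the limit of > 10000 nM in this assay, at which 3 of the 3 values shown sit.

The compounds shown leave open at what concentration compound 1, compound 2 or compound 3 becomes cytotoxic in this assay and how far apart they lie.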